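A few compounds are considered here, and "the series" means these few. Any claim that something is new, unique, unknown or untested is made for them only; others in the source may bear on it.

Measured so far in a functional assay on HeLa cells (Homo sapiens) for antiproliferative activity, read by CCK-8 assay, with a stated time of 72 h; a lower number here means a stronger inhibitor, a higher number a weaker inhibitor:
Compound 1 `Cc1cc(Nc2cc(N3CCN(C)CC3)nc(Nc3ccc([N+](=O)[O-])cc3)n2)n[nH]1`: 331 nM
Compound 2 `COc1cccc(Nc2nc(Nc3cc(C)[nH]n3)cc(N3CCN(C)CC3)n2)c1`: 546 nM
Compound 3 `Cc1cc(Nc2cc(N3CCN(C)CC3)nc(Nc3cccc([N+](=O)[O-])c3)n2)n[nH]1`: 1110 nM

Compound 3 has the highest of these three numbers, which makes it the weakest inhibitor of the set. The gaps to the other two are a 2.0-fold higher number from compound 2 to compound 3 (0.31 log units; beyond the scatter) and a 3.4-fold higher number from compound 1 to compound 3 (0.53 log units; beyond the scatter).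

The next compound is compound 4 `Cc1cc(Nc2cc(N3CCN(C)CC3)nc(Nc3ccc(C#N)cc3)n2)n[nH]1`. In it, 4-cyanophenyl takes the place of 3-nitrophenyl on a nitrogen on an aromatic ring: 4-cyanophenyl in place of 3-nitrophenyl on a nitrogen on an aromatic ring.

The most useful guide is a 3.4-fold higher number from compound 1 to compound 3 (0.53 log units; beyond the scatter), a modest step that shows how much the change between 4-nitrophenyl and 3-nitrophenyl mattered in this series. Read in reverse, it suggests that leaving the 3-nitrophenyl form may bring the number down. A second step, a 1.6-fold higher number from compound 1 to compound 2 (0.22 log units; within the scatter), shows that a quite different group on the same nitrogen need not move the number much. Going by the values given here, no measured pair here exchanges a nitro group for a nitrile, so that part of the change remains unknown. A modest step towards a lower number therefore seems likely, though probably no larger than the one between the two nitro compounds.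

The estimate amounts to an expected 2.2-fold lower number from compound 3 to compound 4 (0.35 log units; beyond the scatter). For compound 4 the expected value is 500 nM, with an estimated range of 170 nM to 1400 nM.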

Compound 4, half-maximal inhibitory concentration: 331 nM
Beside the measured number, compound 4's estimate is 1.5-fold (0.18 log units) above it; low and high end bracket the measured number.
By their numbers in this assay, from the lowest: compounds 1, 4 and 2 (each within the scatter of the next); then compound 3.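

Going by these compounds alone, exchanging the nitro group for a nitrile on an aromatic carbon gives no change at the digits printed from compound 1 to compound 4 (within the scatter) in this assay and so offers the first direct look at this swap, which here leaves the number where it was. Going from 3-nitrophenyl to 4-cyanophenyl on the same nitrogen gives a 3.4-fold lower number from compound 3 to compound 4 (0.53 log units; beyond the scatter) and matches in size the step between the two nitro compounds, a 3.4-fold higher number from compound 1 to compound 3 (0.53 log units; beyond the scatter) so compound 3 is now the weakest of the four, with its step to each of the others printed as beyond the scatter. The comparison with 3-methoxyphenyl gives a 1.6-fold lower number from compound 2 to compound 4 (0.22 log units; within the scatter) which means that 4-nitrophenyl, 4-cyanophenyl and 3-methoxyphenyl all lie within the scatter of one another, and only 3-nitrophenyl goes against that picture. Nothing available here explains why these numbers fall as they do.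

The compounds shown leave open how 3-cyanophenyl or 4-methoxyphenyl would compare, and those two would help separate the effect of the group itself from that of where it sits on the ring. Also open, on these data alone, is what an amine or a carboxylic acid on this phenyl ring would do to the number.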